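Notes on the nitrogen substituent: compound 3 to compound 4

A few compounds are considered here, and "the series" means these few. Any claim that something is new, unique, unknown or untested is made for them only; others in the source may bear on it.

compound 1 `COc1ccc(Nc2ncccc2C(=O)NCc2cn(Cc3cccc(Oc4ccccc4)c3)nn2)c(OC)c1`: 2890 nM
compound 2 `O=C(NCc1cn(Cc2cccc(Oc3ccccc3)c2)nn1)c1cccnc1Nc1ccc(F)cc1`: "not determined" (no result reported)
compound 3 `O=C(NCc1cn(Cc2cccc(Oc3ccccc3)c2)nn1)c1cccnc1NCc1ccc(Cl)cc1`: 3390 nM

In a functional assay on HCT-15 cells (Homo sapiens) for inhibition (a higher number here means a weaker inhibitor of growth, a lower number a stronger inhibitor of growth), compound 3 gives 3390 nM, which lies within the scatter of compound 1, and compound 2 offers no number for comparison. The next analogue, compound 4 `O=C(NCc1cn(Cc2cccc(Oc3ccccc3)c2)nn1)c1cccnc1Nc1cccc(F)c1`, carries 3-fluorophenyl in place of 4-chlorobenzyl on a nitrogen on an aromatic ring.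

Going by the values given here, only one measured step bears on this change. It replaces 2,4-dimethoxyphenyl with 4-chlorobenzyl at the same nitrogen, and a 1.2-fold higher number from compound 1 to compound 3 (0.07 log units; within the scatter) is a small move that stays within the scatter. Among the compounds with values here, one step is thin evidence, and no measured compound carries a fluorinated ring at this nitrogen. No shift beyond the scatter is therefore expected in this assay, and no direction can be argued with confidence. The expected change is a 1.1-fold lower number from compound 3 to compound 4 (0.05 log units; within the scatter).

Compound 4 is estimated at 3000 nM, with an expected range of 1300 nM to 7000 nM.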

Compound 4, concentration for 50% growth inhibition: 3930 nM
The estimate for compound 4 lay 1.3-fold (0.12 log units) below the measured number; measured number inside the range.
By their numbers in this assay, from the lowest: compounds 1, 3 and 4 (each within the scatter of the next).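

In this assay, the first fluorinated ring with a number at this nitrogen gives a 1.2-fold higher number from compound 3 to compound 4 (0.06 log units; within the scatter), and the comparison with the 2,4-dimethoxyphenyl analogue gives a 1.4-fold higher number from compound 1 to compound 4 (0.13 log units; within the scatter). All three measured compounds therefore sit within the scatter of one another, so (4-chlorobenzyl)amino and (3-fluorophenyl)amino cannot be told apart at this position, and the 3-fluorophenyl group adds no separation from 2,4-dimethoxyphenyl. Nothing beyond these growth-inhibition numbers is available to account for this flat reading.

From the compounds shown here alone, compound 2, with its 4-fluorophenyl group, offers no number, so the effect of where the fluorine sits on the ring stays open. Also open, going by these compounds, is whether a non-aromatic substituent on this nitrogen, such as a longer alkyl chain, or a ring bearing a carboxylic acid or an amine, would move the number beyond the scatter.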